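The source may report more compounds than this note shows. Statements on the series, on what has been measured and on what is new or still open speak of the compounds shown alone.

Measured compounds:
compound 1 `Cn1c(=O)c(=O)n(C2CCCC2)c2nc(N/N=C/c3cccc(Cl)c3Cl)ncc21`, 17200 nM; compound 2 `Cn1c(=O)c(=O)n(C2CCCC2)c2nc(N/N=C/c3ccc(F)cc3Cl)ncc21`, 15200 nM; compound 3 `Cn1c(=O)c(=O)n(C2CCCC2)c2nc(N/N=C/c3cc(C(F)(F)F)cc(C(F)(F)F)c3)ncc21`, 8200 nM.

In a functional assay on PC-3 cells (Homo sapiens) for antiproliferative activity, read by MTT assay (on this read-out higher numbers stand for weaker inhibition and lower numbers for stronger inhibition), compound 1 gives the highest of the three numbers. Compound 2 sits nearest to it, the step of a 1.1-fold lower number from compound 1 to compound 2 (0.05 log units; within the scatter), while compound 3 lies furthest, and the gap between compound 1 and compound 3 is beyond the scatter. Compound 4 `Cn1c(=O)c(=O)n(C2CCCC2)c2nc(N/N=C/c3cc([N+](=O)[O-])ccc3Cl)ncc21` differs from compound 1 in one place: 2-chloro-5-nitrophenyl in place of 2,3-dichlorophenyl on a carbon with a double bond to nitrogen. Among the compounds with values here, the only measured step of the same kind, a 1.1-fold lower number from compound 1 to compound 2 (0.05 log units; within the scatter), exchanges one substituted phenyl for another and stays within the scatter, so little movement in this assay is expected, with compound 3 hinting at a modest lowering at most. Compound 4 is therefore estimated at 12000 nM, in the range 5000 nM to 30000 nM, a step of a 1.4-fold lower number from compound 1 to compound 4 (0.16 log units; within the scatter) that is expected.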

Compound 4, half-maximal inhibitory concentration: 9260 nM
The estimate for compound 4 lay 1.3-fold (0.11 log units) above the measured number; low and high end bracket the measured number.
By their numbers in this assay, from the lowest: compounds 3, 4, 2 and 1 (each within the scatter of the next, the first and the last beyond it).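

In this assay, 2-chloro-5-nitrophenyl in place of 2,3-dichlorophenyl gives a step within the scatter (a 1.9-fold lower number from compound 1 to compound 4 (0.27 log units; within the scatter)), and the same holds against 2-chloro-4-fluorophenyl (a 1.6-fold lower number from compound 2 to compound 4 (0.22 log units; within the scatter)). The entering group brings hydrogen-bond acceptors that 2,3-dichlorophenyl lacks, yet in this comparison the read-out does not move beyond the scatter. Nothing measured here offers an explanation for this result. The compounds shown leave open whether an amine or a carboxylic acid on this phenyl ring, or a cyclohexyl group in its place, would shift the number beyond the scatter.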